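The compounds below may be only part of what the source reports. "The series", "measured", "known", "first", "only" and "open" are said of these compounds alone.

In an ADME assay on tissue (MIA PaCa-2 cells, Homo sapiens) for pharmacokinetics (a lower number here means that the compound disappears faster, a higher number that the compound lasts longer), compound 1 (`CC(C)[C@H](N)C(=O)OC[C@H]1O[C@@H](n2cc(F)c(=O)[nH]c2=O)C[C@@H]1OC(=O)[C@@H](N)C(C)C`) gives 0.14 h, while compound 2 (`N[C@@H](CC(=O)O[C@H]1C[C@H](n2cc(F)c(=O)[nH]c2=O)O[C@@H]1CO)C(=O)O`) gives 0.535 h. Compound 2 thus stands highest of the two numbers, and its gap to compound 1 lies beyond the usual scatter. Compound 3 (`CC(C)[C@H](N)C(=O)O[C@H]1C[C@H](n2cc(F)c(=O)[nH]c2=O)O[C@@H]1CO`) departs from compound 2 at one place, on a carbonyl carbon whose other neighbours are oxygen: 1-amino-2-methylpropyl in place of 2-amino-2-carboxyethyl on a carbonyl carbon. In words, 1-amino-2-methylpropyl takes the place of 2-amino-2-carboxyethyl. For the measured compounds named here, no measured pair isolates this change, so the evidence is thin. Compound 3 differs elsewhere from compound 1, which also carries 1-amino-2-methylpropyl. Compound 1 gives 0.14 h. On that basis a small fall within the scatter is expected, an estimated 1.5-fold lower number from compound 2 to compound 3 (0.18 log units; within the scatter). For compound 3 the expected value in this assay is 0.35 h, with an estimated range of 0.14 h to 0.9 h.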

Compound 3, half-life: 0.203 h
Compound 3: the middle estimate sits 1.7-fold (0.24 log units) above what was measured; measured number inside the range.
By their numbers in this assay, from the lowest: compounds 1 and 3 (each within the scatter of the next); then compound 2.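

In this assay, for the compounds shown here, 1-amino-2-methylpropyl in place of 2-amino-2-carboxyethyl on a carbonyl carbon gives a 2.6-fold lower number from compound 2 to compound 3 (0.42 log units; beyond the scatter), which is the first isolated reading of this change and shows that the group at this position moves the half-life. The higher number goes with 2-amino-2-carboxyethyl, but that rests on this single pair. The second change, hydrogen in place of (1-amino-2-methylpropyl)carbonyl on an oxygen on a saturated carbon, gives a 1.5-fold higher number from compound 1 to compound 3 (0.16 log units; within the scatter), so that group makes no readable difference here. Going by these compounds, whether a simple amine, a carboxylic acid without the amino group or a longer chain at the same carbonyl carbon would shift the number remains open. So does whether 2-amino-2-carboxyethyl would hold its number with a second group on the other oxygen. Nothing available here gives a reason for either step.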